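Amide side chain variation in a kinase inhibitor series

The source may hold more compounds than are shown below. What is called first, only, known or untested is meant among the compounds shown, and "the series" means these compounds.

Measured compounds:
Compound 1, `CN1CCC(NC(=O)c2cc(-c3ccc(NS(=O)(=O)c4cccc(Cl)c4Cl)cc3)nc3[nH]ncc23)C1`, gives 21 nM in an assay for inhibition of serine/threonine-protein kinase Sgk1 (Homo sapiens), with stated times of 30 min and 60 min, in the presence of a further agent that is not named here; a lower number here means a stronger inhibitor, a higher number a weaker inhibitor.
Compound 2, `CC(C)N1CC[C@H](NC(=O)c2cc(-c3ccc(NS(=O)(=O)c4cccc(Cl)c4Cl)cc3)nc3[nH]ncc23)C1`, gives 38 nM in this assay.
Compound 3, `CNC(=O)c1cc(-c2ccc(NS(=O)(=O)c3cccc(Cl)c3Cl)cc2)nc2[nH]ncc12`, gives 929 nM in this assay.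

Compound 3 has the highest number of the three in this assay. Its nearest neighbour is compound 2, and the step of a 24-fold higher number from compound 2 to compound 3 (1.39 log units; beyond the scatter) is large; the step of a 44-fold higher number from compound 1 to compound 3 (1.65 log units; beyond the scatter) is larger still. Between the two pyrrolidinyl amides the step of a 1.8-fold higher number from compound 1 to compound 2 (0.26 log units; within the scatter) is small.

Compound 4, `NCCNC(=O)c1cc(-c2ccc(NS(=O)(=O)c3cccc(Cl)c3Cl)cc2)nc2[nH]ncc12`, differs from compound 3 by aminomethyl in place of hydrogen on a saturated chain carbon bound to an amide-type nitrogen. The change turns the methyl amide into a 2-aminoethyl amide, so that the side chain on the amide-type nitrogen again carries a basic nitrogen, as it does in compound 1 and compound 2. Both steps from those compounds to compound 3 bear on the question: removing the amine-bearing pyrrolidinyl in favour of methyl cost a great deal. Reintroducing an amine on a flexible chain is therefore expected to bring a large step downward in this assay, though the open chain need not match the ring. Compound 4 is estimated at 90 nM, within 25 nM to 350 nM, which would mean a step of a 10-fold lower number from compound 3 to compound 4 (1.01 log units; beyond the scatter).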

Compound 4, half-maximal inhibitory concentration: < 1 nM
Compound 4: no number, only a limit (the forecaster's own chance of this, stated with the estimate: 2%); middle value at least 90-fold (1.95 log units) from the limit.
By their numbers in this assay, from the lowest: compounds 1 and 2 (each within the scatter of the next); then compound 3. At a limit, below all of these: compound 4.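

The value for compound 4 in this assay is a limit and not a number: the limit of < 1 nM in this assay, at which 1 of the 4 values shown sits. On the amide-type nitrogen, the change from methyl to 2-aminoethyl gives an at least 920-fold lower number from compound 3 to compound 4 (2.96 log units; beyond the scatter), so adding a single aminomethyl on the saturated chain carbon does more than restore what the methyl amide lacks relative to the pyrrolidinyl amides. The earlier compounds shown here showed only that both pyrrolidinyl side chains gave lower numbers than methyl, whereas this result shows that the ring is not required at this position and that an open chain goes beyond either ring-bearing side chain: an at least 38-fold lower number from compound 2 to compound 4 (1.57 log units; beyond the scatter), and an at least 21-fold lower number from compound 1 to compound 4 (1.32 log units; beyond the scatter).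

Going by these compounds, how far below the limit compound 4 really lies remains open, and with it the full size of all three steps. Also open, on these data alone, is whether the amine itself accounts for the gain, which a 2-hydroxyethyl amide would test, and whether the gain would hold with a longer chain such as 3-aminopropyl or a substituted amine such as 2-(dimethylamino)ethyl.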